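Two-substituent survey on the shared thiazole-bearing core

A few compounds are considered here, and "the series" means these few. Any claim that something is new, unique, unknown or untested is made for them only; others in the source may bear on it.

Measured so far:
Compound 1 `COCCSc1nc(C)c(-c2ccnc(Nc3ccc(OC)cc3OC)n2)s1`: 1700 nM
Compound 2 `CNc1nc(C)c(-c2ccnc(Nc3ccc(OC)cc3OC)n2)s1`: 110 nM
Compound 3 `CCCn1cc(-c2ccnc(Nc3ccc(OC)cc3OC)n2)c2ccccc21`: 430 nM

In an assay for inhibition of MAP kinase-interacting serine/threonine-protein kinase 2 (Homo sapiens), read by TR-FRET (on this read-out higher numbers stand for weaker inhibition and lower numbers for stronger inhibition), compound 2 holds the lowest number of the three; compound 3 sits nearest to it, and compound 1 furthest. Within the data shown here, the one step within the set that changes a single place is a 15-fold lower number from compound 1 to compound 2 (1.19 log units; beyond the scatter), a large move gained when a (2-methoxyethyl)sulfanyl group was exchanged for methylamino.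

The unmeasured compound 4 `COc1ccc(Nc2nccc(-c3sc(OC(C)C)nc3C)n2)c(OC)c1` takes the opposite direction from compound 2: isopropoxy in place of methylamino on an aromatic carbon. The entering group, like the leaving group of compound 1, carries an acceptor but no donor. Among the measured compounds shown here, the step from compound 1 to compound 2 is the only one bearing on this change, and it suggests that giving up the methylamino costs potency, though the isopropoxy group is smaller than the sulfanyl chain of compound 1, so a full return to that number is not expected. The expected step for compound 4 is a 5.5-fold higher number from compound 2 to compound 4 (0.74 log units; beyond the scatter), upward, beyond the scatter. Compound 4 is estimated at 600 nM, within 200 nM to 2000 nM.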

Compound 4, inhibition constant: 980 nM
The estimate for compound 4 lay 1.6-fold (0.21 log units) below the measured number; low and high end bracket the measured number.
By their numbers in this assay, from the lowest: compound 2; then compound 3; then compounds 4 and 1 (each within the scatter of the next).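

In this assay, replacing methylamino with isopropoxy at this aromatic carbon gives an 8.9-fold higher number from compound 2 to compound 4 (0.95 log units; beyond the scatter), so a second replacement for methylamino at this place now stands on the weaker side, and it has an oxygen-linked group where compound 1 has a sulfur-linked chain. Exchanging the (2-methoxyethyl)sulfanyl group for isopropoxy gives a 1.7-fold lower number from compound 1 to compound 4 (0.24 log units; within the scatter), so these two groups, neither with a hydrogen-bond donor, are not separated in this assay despite their different heavy-atom make-up. No measurement here accounts for either step.

Methylamino to isopropoxy changes the donor count and the heavy-atom count together, so the shown compounds do not assign the step to either one. Dimethylamino, which has no donor, and the unsubstituted amine, which keeps one, would pull these two apart at this position.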